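From 4-aminopiperidin-1-yl to 3-aminopiperidin-1-yl

The source may hold more compounds than are shown below. What is called first, only, known or untested is meant among the compounds shown, and "the series" means these compounds.

Of the compounds shown here, two sharing one core have been tested so far. In a functional assay on V79 cells (Cricetulus griseus) for cytotoxicity, read by colony formation (on this read-out lower numbers stand for stronger inhibition and higher numbers for weaker inhibition), compound 1 `NCC1CCN(c2c(F)cc3c(=O)c(C(=O)O)cn(C4CC4)c3c2C(F)(F)F)C1` gives 38 ug/mL, and compound 2 `NC1CCN(c2c(F)cc3c(=O)c(C(=O)O)cn(C4CC4)c3c2C(F)(F)F)CC1` gives 20 ug/mL. Compound 2 therefore has no clear standing apart from compound 1, since the two values lie within the usual scatter of each other.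

Compound 3 `NC1CCCN(c2c(F)cc3c(=O)c(C(=O)O)cn(C4CC4)c3c2C(F)(F)F)C1` has the same atoms as compound 2, joined differently: 3-aminopiperidin-1-yl in place of 4-aminopiperidin-1-yl on an aromatic carbon. The new group sits on the same aromatic carbon.

Among the measured compounds shown here, only one measured step bears on this, the exchange of 3-(aminomethyl)pyrrolidin-1-yl for 4-aminopiperidin-1-yl, which is a 1.9-fold lower number from compound 1 to compound 2 (0.28 log units; within the scatter). That is a single small step, so no change beyond the scatter is expected in this assay. The expected step is a 1.3-fold higher number from compound 2 to compound 3 (0.10 log units; within the scatter). The estimated value for compound 3 is 25 ug/mL, within an expected range of 10 ug/mL to 60 ug/mL.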

Compound 3, half-maximal inhibitory concentration: > 500 ug/mL
Compound 3 ended at the assay's limit; the forecaster's own chance of this, stated with the estimate: 5%; at least 20-fold (1.30 log units) between middle value and limit.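

In this assay, among the compounds shown here, the exchange at this aromatic carbon, ortho to a fluoro group and ortho to a trifluoromethyl group, shows that the way the ring is joined can matter far more than the earlier compounds suggested: 3-aminopiperidin-1-yl in place of 4-aminopiperidin-1-yl, with the same atoms, gives an at least 25-fold higher number from compound 2 to compound 3 (1.39 log units; beyond the scatter). Replacing 3-(aminomethyl)pyrrolidin-1-yl with the same group also gives a step beyond the scatter, an at least 13-fold higher number from compound 1 to compound 3 (1.11 log units; beyond the scatter), unlike the small step between the two earlier compounds. The value of compound 3 is a limit of the assay and not a number: the limit of > 500 ug/mL in this assay, at which 1 of the 3 values shown sits.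

Going by these compounds, whether a 3-aminopyrrolidin-1-yl or a 3-(methylamino)piperidin-1-yl group at this carbon would also give a high number remains open. On these data alone, all three compounds share one core, so it is also open whether this exchange would behave alike with a chloro group in place of the trifluoromethyl group.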